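Compound 3: dichlorophenyl in place of phenyl in compound 1

The source may report more compounds than this note shows. Statements on the series, on what has been measured and on what is new or still open speak of the compounds shown alone.

Measured compounds:
compound 1 `COc1cc2c(Oc3ccc(NC(=O)c4cc(-c5ccccc5)nc5ccccc45)cc3F)ccnc2cc1OCCCN1CCCCC1` in a functional assay on HT-29 cells (Homo sapiens) for cytotoxicity, read by MTT assay, with a stated time of 72 h (a lower number here means a stronger inhibitor, a higher number a weaker inhibitor), gives 530 nM
compound 2 `COc1cccc(-c2cc(C(=O)Nc3ccc(Oc4ccnc5cc(OCCCN6CCCCC6)c(OC)cc45)c(F)c3)c3ccccc3n2)c1` in this assay gives 1740 nM

Going by the values given here, compound 1 stands lowest of the two numbers so far in this assay; the nearest is compound 2, reached by a 3.3-fold higher number from compound 1 to compound 2 (0.52 log units; beyond the scatter), a step that is beyond the scatter but modest.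

Compound 3 `COc1cc2c(Oc3ccc(NC(=O)c4cc(-c5ccc(Cl)c(Cl)c5)nc5ccccc45)cc3F)ccnc2cc1OCCCN1CCCCC1` differs from compound 1 by 3,4-dichlorophenyl in place of phenyl on an aromatic carbon. Among the compounds with values here, the only measured step that bears on this is the one from compound 1 to compound 2, also a substituent change on an aromatic carbon of the shared core, and it gave a higher number. Within the data shown here, no measured step involves chlorine, so the bearing is loose. A modest rise in this assay is therefore expected for compound 3, of roughly the size a 1.7-fold higher number from compound 1 to compound 3 (0.23 log units; within the scatter), though a result within the scatter of compound 1 would not surprise. For compound 3 the estimate in this assay is 900 nM, within 350 nM to 2500 nM.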

Compound 3, half-maximal inhibitory concentration: 1210 nM
Compound 3: the middle estimate sits 1.3-fold (0.13 log units) below what was measured, within the range that was stated.
By their numbers in this assay, from the lowest: compound 1; then compounds 3 and 2 (each within the scatter of the next).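

In this assay, 3,4-dichlorophenyl in place of phenyl, on the aromatic carbon next to the ring nitrogen, gives a 2.3-fold higher number from compound 1 to compound 3 (0.36 log units; beyond the scatter), so a second kind of substituted phenyl at this position also carries a higher number than unsubstituted phenyl, and none of the three compounds goes against this. The two substituted rings are not separated, with a 1.4-fold lower number from compound 2 to compound 3 (0.16 log units; within the scatter), so 3,4-dichlorophenyl and 3-methoxyphenyl cannot be ranked in this assay. No measurement bears on why substitution on this phenyl goes with a higher number.

Open, from the compounds shown here alone, is whether a single chlorine gives the same step as the two chlorines of 3,4-dichlorophenyl. Also open, going by these compounds, is how an amine or a carboxylic acid on this phenyl would compare with compound 1.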